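The compounds below may be only part of what the source reports. "The series", "measured", "known", "first", "only" and "open" are said of these compounds alone.

Compound 3 `COc1c(F)cccc1N1C(=O)CSC1c1cccc(C(=O)NCCCCc2ccccc2)c1` gives 5% in a functional assay on 143B cells (Homo sapiens) for inhibition, read by CCK-8 assay, with a stated time of 72 h, tested at 1 uM (on this read-out higher numbers stand for more inhibition at the one concentration tested (going by the name of the read-out) and lower numbers for less inhibition), the lowest of the three numbers in hand. Compound 1 `O=C(NCCCCc1ccccc1)c1cccc(C2SCC(=O)N2c2cccc(F)c2)c1` gives 63% and compound 2 `COc1cc(F)ccc1N1C(=O)CSC1c1cccc(C(=O)NCCCCc2ccccc2)c1` gives 63%, each well beyond the scatter above compound 3. Compound 4 `COc1ccc(F)cc1N1C(=O)CSC1c1cccc(C(=O)NCCCCc2ccccc2)c1` is the next step, with the change (5-fluoro-2-methoxyphenyl in place of 3-fluoro-2-methoxyphenyl on an amide-type nitrogen in a ring).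

Among the compounds with values here, two measured steps bear on this. The step of a number 58 percentage points lower from compound 2 to compound 3 (beyond the scatter) shows that swapping one fluoro-methoxyphenyl for another on this nitrogen can move the read-out a great deal. The step of no change at the digits printed from compound 1 to compound 2 (within the scatter), by contrast, shows that a different fluoro-methoxyphenyl left the number where it was, and a number 58 percentage points lower from compound 1 to compound 3 (beyond the scatter) repeats the large drop. Compound 4 carries a third arrangement, so a large move in either direction is possible. It is expected that compound 4 recovers much of the ground lost, with the estimated step of a number 45 percentage points higher from compound 3 to compound 4 (beyond the scatter). The estimate for compound 4 in this assay is 50%, between 15% and 75%.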

Compound 4, a percentage reported as inhibition, at one concentration (the size of the read-out at that concentration, not a potency): 62%
Estimate against measurement, compound 4: 12 percentage points below; low and high end bracket the measured number.
By their numbers in this assay, from the lowest: compound 3; then compounds 4, 1 and 2 (each within the scatter of the next).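

Moving only the fluorine while keeping the methoxy gives a number 57 percentage points higher from compound 3 to compound 4 (beyond the scatter), so the methoxy group alone does not bring the loss seen with compound 3; that loss goes with the 3-fluoro-2-methoxyphenyl arrangement. The same methoxy-for-hydrogen change that took compound 1 to the low number of compound 3 can also leave the number in place, as in a number 1 percentage points lower from compound 1 to compound 4 (within the scatter). The other fluorine arrangement behaves alike, with a number 1 percentage points lower from compound 2 to compound 4 (within the scatter), so compound 3 is the only one of the four that stands apart.

No measurement in hand explains why one arrangement differs so sharply from the others. Going by these compounds, whether an ethoxy in place of the methoxy, or a chloro in place of the fluoro, would keep the number of compound 4 remains open.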